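The compounds below may be only part of what the source reports. "The series", "measured", "known", "first", "only" and "open" are said of these compounds alone.

Compound 2 `CC1(C)N(O)C(c2ccc(OCC(=O)NCCCC[C@H](N)C(=O)O)cc2)=[N+]([O-])C1(C)C` and compound 1 `CC1(C)N(O)C(c2ccc(OCC(=O)N[C@@H](CCCCN)C(=O)O)cc2)=[N+]([O-])C1(C)C` share one core and differ only in the amino acid attached to the amide nitrogen. In a functional assay on PC-12 cells (Rattus norvegicus) for inhibition, read by MTT assay (on this read-out lower numbers stand for an effect already at smaller amounts and higher numbers for an effect only at larger amounts of compound), compound 2 gives 98800 nM, the lowest of the two numbers but within the scatter of compound 1, which gives 99100 nM. That single step, a 1.0-fold lower number from compound 1 to compound 2 (0.00 log units; within the scatter), shows that rearranging this amino acid left the number essentially unchanged. Compound 3 `CC1(C)N(O)C(c2ccc(OCC(=O)N[C@@H](CCCNC(=N)N)C(=O)O)cc2)=[N+]([O-])C1(C)C` carries a further exchange, (a group of 11 heavy atoms (6 carbon, 3 nitrogen, 2 oxygen; no ring) in place of a group of 9 heavy atoms (6 carbon, 1 nitrogen, 2 oxygen; no ring), on an amide-type nitrogen). Among the measured compounds shown here, no measured step covers this change, so compound 3 is expected to stay close, with a step of a 1.0-fold higher number from compound 2 to compound 3 (0.00 log units; within the scatter) and an estimate of 99000 nM, between 40000 nM and 250000 nM.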

Compound 3, half-maximal effective concentration: 101000 nM
Beside the measured number, compound 3's estimate is 1.0-fold (0.01 log units) below it; the measured number falls inside the stated range.
By their numbers in this assay, from the lowest: compounds 2, 1 and 3 (each within the scatter of the next).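

Moving from a rearranged amino acid to a different end group on the amide-type nitrogen still leaves the number in place in this assay: there is a 1.0-fold higher number from compound 2 to compound 3 (0.01 log units; within the scatter), and there is a 1.0-fold higher number from compound 1 to compound 3 (0.01 log units; within the scatter). So even a larger group, with more nitrogen on the saturated chain carbon and more hydrogen-bond donors, gives a step within the scatter. Nothing measured here offers a reason for this. All three compounds keep a carboxylic acid and a basic nitrogen-bearing chain on the amide-type nitrogen. As far as these compounds go, whether a simple phenyl ring or a short methyl group there would shift the number remains open.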